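This account rests on a few compounds, and the source may have more. Where it says the series, first, only, none or still open, it means among the compounds named here.

Compound 1 `N#Cc1ccc(NC(=O)c2cc(-c3ccncc3)ccc2O)cc1`: 5410 nM
Compound 2 `O=C(Nc1ccc(Cl)cc1Cl)c1cc(F)ccc1O`: 890 nM
Compound 3 `O=C(Nc1ccc(OC(F)(F)F)c(Cl)c1)c1cc(F)ccc1O`: 550 nM

These three compounds have been tested in a functional assay on HL-60 cells (Homo sapiens) for cytotoxicity, read by luminescence and CellTiter-Glo, with a stated time of 3 days; a higher number here means a weaker inhibitor, a lower number a stronger inhibitor. Compound 1 gives the highest number of the three, which makes it the weakest inhibitor in this set. Its distance from each of the other two, compound 2 and compound 3, lies beyond the scatter.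

Compound 4 `N#Cc1ccc(NC(=O)c2cc(-c3cccnc3)ccc2O)cc1` has not yet been measured. It carries pyridin-3-yl in place of pyridin-4-yl on an aromatic carbon, para to a hydroxy group, and the rest of compound 1 stays the same (pyridin-3-yl in place of pyridin-4-yl on an aromatic carbon). Among the measured compounds shown here, no measured pair shows a change of this kind, and neither compound 2 nor compound 3 carries pyridin-4-yl. For the measured compounds named here, the only guide is therefore compound 1 at 5410 nM, and no step beyond the scatter is expected in this assay. The estimated step is a 1.2-fold lower number from compound 1 to compound 4 (0.08 log units; within the scatter). For compound 4 the expected value is 4500 nM, with an estimated range from 1800 nM to 10000 nM.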

Compound 4, half-maximal inhibitory concentration: 7960 nM
Beside the measured number, compound 4's estimate is 1.8-fold (0.25 log units) below it, and the stated range covers the measured number.
By their numbers in this assay, from the lowest: compounds 3 and 2 (each within the scatter of the next); then compounds 1 and 4 (each within the scatter of the next).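

Exchanging pyridin-4-yl for pyridin-3-yl on this aromatic carbon, para to a hydroxy group, gives a 1.5-fold higher number from compound 1 to compound 4 (0.17 log units; within the scatter) in this assay. This is the only pair shown that differs in one place, and it shows that, in this assay, the two pyridine attachments cannot be told apart at this position, although the two compounds hold the same atoms joined differently. Nothing available here bears on the reason for this result.

As far as these compounds go, whether a phenyl ring, an amine or a carboxylic acid on this same carbon would give a number outside the scatter of these two remains open. Compound 2 and compound 3 differ from this pair in more than one place, so what sets their numbers apart from it is also unresolved.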